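Replacing sec-butylamino with diisopropylamino on a chlorotriazine

The source may report more compounds than this note shows. Statements on the series, on what has been measured and on what is new or still open speak of the compounds shown alone.

Compound 1 `CC(C)N(c1nc(Cl)nc(N[C@@H](C)c2ccccc2)n1)C(C)C` gives 110 nM in an ADME assay on the whole organism for inhibition, with Echinochloa crus-galli var. formosensis as the target, with a stated time of 4 days; on this read-out higher numbers stand for weaker inhibition and lower numbers for stronger inhibition. Compound 2 `CC[C@@H](C)Nc1nc(Cl)nc(N[C@H](C)c2ccccc2)n1` gives 4570 nM in this assay. Compound 3 `CC[C@@H](C)Nc1nc(Cl)nc(N[C@@H](C)c2ccccc2)n1` gives 7410 nM in this assay.

Compounds 2 and 3 share the same atoms and bonds; their difference is the two compounds have the same atoms and bonds and differ only in configuration as drawn: 1 of 2 stereo elements differ; a stereocentre at a saturated chain carbon is drawn S in compound 3 and R in compound 2. Their values sit a 1.6-fold higher number from compound 2 to compound 3 (0.21 log units; within the scatter), which is consistent with the fact that compounds 2 and 3 differ only in the configuration as drawn. The change from compound 3 to compound 1 is diisopropylamino in place of (sec-butyl)amino on an aromatic carbon, and it produced a step of a 67-fold lower number from compound 3 to compound 1 (1.83 log units; beyond the scatter).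

Compound 4 `CC(C)N(c1nc(Cl)nc(N[C@H](C)c2ccccc2)n1)C(C)C` has not yet been measured. It arises from compound 2 by diisopropylamino in place of (sec-butyl)amino on an aromatic carbon, the same change as that from compound 3 to compound 1, made at the same place. Resting on a 67-fold lower number from compound 3 to compound 1 (1.83 log units; beyond the scatter) and on the value of compound 2 4570 nM, a step of similar size is expected, namely a 65-fold lower number from compound 2 to compound 4 (1.81 log units; beyond the scatter). Compound 4 is therefore estimated at 70 nM, with a range from 20 nM to 250 nM.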

Compound 4, half-maximal inhibitory concentration: 6610 nM
Compound 4: middle estimate off by 94-fold (1.98 log units), on the low side; measured number above the stated range.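

In this assay, the change from (sec-butyl)amino to diisopropylamino does not carry over from one core to the other: the same change on two cores in this assay, a 67-fold lower number (1.83 log units; beyond the scatter) from compound 3 to compound 1 and a 1.4-fold higher number (0.16 log units; within the scatter) from compound 2 to compound 4, 97-fold (1.99 log units) apart, beyond the scatter of two such steps. The new step is a 1.4-fold higher number from compound 2 to compound 4 (0.16 log units; within the scatter), while configuration alone separates the two diisopropylamino compounds, with a 60-fold higher number from compound 1 to compound 4 (1.78 log units; beyond the scatter), and does not separate the two (sec-butyl)amino compounds, with a 1.6-fold higher number from compound 2 to compound 3 (0.21 log units; within the scatter). This shows that the outcome of the change depends on the configuration drawn at the saturated chain carbon in these pairs, but with one pair per core it does not show why, nor that the same would hold for other amino groups.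

The compounds shown leave open whether a diethylamino or a piperidine group in that place would follow the same split between the two configurations. They also leave open whether the split would survive a methoxy group in place of the chloro group.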